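Swapping a pyridine for an imidazole on a cell-growth inhibitor

The source may report more compounds than this note shows. Statements on the series, on what has been measured and on what is new or still open speak of the compounds shown alone.

Compound 1 `CCN(c1ccc(C#N)c(Cl)c1)c1cc(-c2ccncc2)ccc1C` was tested in a functional assay on PC-3 cells (Homo sapiens) for antiproliferative activity, read by CCK-8 assay, with a stated time of 6 days (a lower number here means a stronger inhibitor, a higher number a weaker inhibitor), and gives 3580 nM, the lower of the two numbers reported. Compound 3 `N#Cc1ccc(N2CCc3cc(-c4cnc5ccccc5c4)ccc3C2)cc1C(F)(F)F` gives 25100 nM in this assay, a weaker result well beyond the usual scatter. Compound 2 `N#Cc1ccc(N2CCc3cc(-c4cnc5ccccc5c4)ccc32)cc1C(F)(F)F` gives "not determined" (no result reported) in this assay. Within the data shown here, since compound 3 and compound 1 differ in several places at once, no single step between measured compounds is available to guide a prediction.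

Compound 4 `CCN(c1ccc(C#N)c(Cl)c1)c1cc(-n2ccnc2)ccc1C` differs from compound 1 in one place: 1H-imidazol-1-yl in place of pyridin-4-yl on an aromatic carbon. The rest of the shared core stays the same. The step of a 2.2-fold higher number from compound 1 to compound 4 (0.35 log units; beyond the scatter) is expected to be modest, toward a weaker inhibitor. Compound 4 is estimated to give 8000 nM in this assay, within a range from 2000 nM to 30000 nM.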

Compound 4, half-maximal inhibitory concentration: > 30000 nM
Compound 4 ended at the assay's limit (the forecaster's own chance of this, stated with the estimate: 10%); middle value at least 3.7-fold (0.57 log units) from the limit.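

In this assay, the group on this aromatic carbon is not freely exchangeable: 1H-imidazol-1-yl in place of pyridin-4-yl gives an at least 8.3-fold higher number from compound 1 to compound 4 (0.92 log units; beyond the scatter). Among these compounds, this is the first single change that can be read, and it costs much more activity than a swap of one aromatic ring for another might suggest. Compound 4 gives a limit of the assay rather than a number, so the true size of the loss stays unknown: the limit of > 30000 nM in this assay, at which 1 of the 4 values shown sits.

Going by these compounds, whether a plain phenyl ring or an amine such as morpholine at this place would match compound 1 remains open. Which feature of the two rings drives the difference also remains open.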